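Replacing Benzofuranyl with Isoquinolinyl on a Threonine Amide

This account rests on a few compounds, and the source may have more. Where it says the series, first, only, none or still open, it means among the compounds named here.

Measured so far:
compound 1, `CCCCCCCCCCCCCCCCCCNC(=O)[C@@H](N)[C@@H](C)O`, gives 44500 nM
compound 2, `CCCCCCCCCCCCCCCCCCNC(=O)[C@@H](NC(=O)c1cc2ccccc2o1)[C@@H](C)O`, gives only a limit, > 200000 nM

In a functional assay on HepG2 cells (Homo sapiens) for cytotoxicity, read by MTT assay, with a stated time of 48 h (a lower number here means a stronger inhibitor, a higher number a weaker inhibitor), compound 1 gives 44500 nM. For compound 2 the assay reports only a limit, > 200000 nM, so no exact number is known for it. The step of an at least 4.4-fold higher number from compound 1 to compound 2 (0.65 log units; beyond the scatter) is therefore a minimum, and compound 2 stands at the limit of > 200000 nM in this assay, at which 1 of the 2 values shown sits.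

Compound 3, `CCCCCCCCCCCCCCCCCCNC(=O)[C@@H](NC(=O)c1nccc2ccccc12)[C@@H](C)O`, differs from compound 2 by isoquinolin-1-yl in place of 1-benzofuran-2-yl on a carbonyl carbon. Among the measured compounds shown here, the only measured step, an at least 4.4-fold higher number from compound 1 to compound 2 (0.65 log units; beyond the scatter), concerns attaching an acyl group to the amine nitrogen, not exchanging one bicyclic aromatic acyl group for another, so it gives little direct guidance. Compound 3 is expected to stay close to compound 2, with a number no higher from compound 2 to compound 3 (the limit leaves the size open) as the expected step, most likely again only a limit. The estimate for compound 3 is 200000 nM, expected to lie between 80000 nM and 500000 nM.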

Compound 3, half-maximal inhibitory concentration: 96900 nM
Compound 3: middle estimate off by 2.1-fold (0.31 log units), on the high side; low and high end bracket the measured number.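

In this assay, the identity of the acyl group on the amine nitrogen matters, not only its presence: exchanging one bicyclic group for the other gives an at least 2.0-fold lower number from compound 2 to compound 3 (0.31 log units; beyond the scatter). The size of that change stays open, as the reading for compound 2 is only a limit: the limit of > 200000 nM in this assay, at which 1 of the 3 values shown sits.

Acylation with the new group still leaves a weaker compound than the free amine, with a 2.2-fold higher number from compound 1 to compound 3 (0.34 log units; beyond the scatter), but now as an exact number rather than a limit.

The compounds shown leave open whether the ring nitrogen of isoquinolin-1-yl or the change from a five-membered to a six-membered ring accounts for the difference, as both change together in this one exchange. Also open, on these data alone, is how a simple benzoyl or acetyl group on the amine nitrogen, or a shorter chain on the amide, would read in this assay.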